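The compounds below may be only part of what the source reports. "The series", "measured", "known", "first", "only" and "open" are said of these compounds alone.

Compound 3 (`CCCn1c(=O)c2nc(-c3cnn(Cc4cccc(Cl)c4)c3)[nH]c2n(CCC)c1=O`) gives the lowest number of the three measured in an in vitro assay on HEK293 cells for displacement of a labelled ligand from adenosine receptor A2b (Homo sapiens) (a higher number here means a weaker inhibitor, a lower number a stronger inhibitor), at 18 nM; compound 2 (`CCCn1c(=O)c2nc(-c3cnn(Cc4ccccc4C(F)(F)F)c3)[nH]c2n(CCC)c1=O`) gives 37 nM and compound 1 (`CCCn1c(=O)c2nc(-c3cnn(Cc4ccc(F)cc4F)c3)[nH]c2n(CCC)c1=O`) gives 700 nM. The measured steps are a 19-fold lower number from compound 1 to compound 2 (1.28 log units; beyond the scatter), a 39-fold lower number from compound 1 to compound 3 (1.59 log units; beyond the scatter) and a 2.1-fold lower number from compound 2 to compound 3 (0.31 log units; beyond the scatter). Compound 4 (`CCCn1c(=O)c2nc(-c3cnn(Cc4cc(F)ccc4Cl)c3)[nH]c2n(CCC)c1=O`) differs from compound 3 by 2-chloro-5-fluorophenyl in place of 3-chlorophenyl on a saturated chain carbon bound to an aromatic nitrogen. Among the measured compounds the arrangement of halogens on this phenyl moves the number by large amounts, with compound 1 the weakest and compound 3 the strongest; no measured step alters a 3-chlorophenyl directly, so the new arrangement is read as uncertain but likely to cost some potency. For compound 4 a modest move to a higher number in this assay is expected, a 2.2-fold higher number from compound 3 to compound 4 (0.35 log units; beyond the scatter). Compound 4 is estimated at 40 nM, with a range of 12 nM to 130 nM.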

Compound 4, inhibition constant: 4800 nM
Estimate against measurement, compound 4: 120-fold (2.08 log units) below, and the stated range ends below it.
By their numbers in this assay, from the lowest: compound 3; then compound 2; then compound 1; then compound 4.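

In this assay, keeping a chlorine on the phenyl does not preserve potency at this position: 2-chloro-5-fluorophenyl in place of 3-chlorophenyl gives a 270-fold higher number from compound 3 to compound 4 (2.43 log units; beyond the scatter). The same group also loses heavily against 2-(trifluoromethyl)phenyl, with a 130-fold higher number from compound 2 to compound 4 (2.11 log units; beyond the scatter), and falls short even of 2,4-difluorophenyl, with a 6.9-fold higher number from compound 1 to compound 4 (0.84 log units; beyond the scatter). The two compounds with fluorine directly on the phenyl, compound 1 and compound 4, now hold the two highest numbers. Nothing available bears on the reason for these steps.

The compounds shown do not separate the effect of moving the chlorine from that of adding the fluorine. Going by these compounds, how a methoxy group or a nitrile on the phenyl would behave also remains open.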